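A Second Hydroxy Group on the Chlorinated Core

The source may hold more compounds than are shown below. What is called first, only, known or untested is meant among the compounds shown, and "the series" means these compounds.

Compound 1 `Oc1ccccc1/C=C/c1ccc2cccc(O)c2n1` and compound 2 `Oc1ccc(/C=C/c2ccc3cccc(O)c3n2)c(O)c1` differ by a single change: hydroxy in place of hydrogen on an aromatic carbon. In a physicochemical assay for lipophilicity, read by HPLC (on this read-out lower numbers stand for lower lipophilicity and higher numbers for higher lipophilicity), compound 1 gives 3.95, and compound 2 gives 3.56. The step is a number 0.39 log units lower from compound 1 to compound 2 (beyond the scatter). Compound 3 `Oc1ccc(/C=C/c2ccc3c(Cl)cc(Cl)c(O)c3n2)cc1` rests on a different core; how its core differs from that of compound 1 is not broken down here. In this assay compound 3 gives 5.07, the highest of the three measured values. Compound 4 `Oc1ccc(/C=C/c2ccc3c(Cl)cc(Cl)c(O)c3n2)c(O)c1` has not yet been measured and is reached from compound 3 by hydroxy in place of hydrogen on an aromatic carbon. This is the same kind of change as that from compound 1 to compound 2, though the place differs: here the hydroxy enters ortho to a large group and meta to a hydroxy group, whereas earlier it entered meta to a hydroxy group and para to a large group. Because of a number 0.39 log units lower from compound 1 to compound 2 (beyond the scatter), the step of a number 0.37 log units lower from compound 3 to compound 4 (beyond the scatter) is expected to be of similar size. Compound 4 is therefore estimated at 4.7, with a range from 4.3 to 5.1.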

Compound 4, partition coefficient: 4.68
Compound 4: the middle estimate sits 0.02 log units above what was measured; low and high end bracket the measured number.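

Two steps of the same size stand here: in this assay hydroxy in place of hydrogen on an aromatic carbon gives a number 0.39 log units lower from compound 3 to compound 4 (beyond the scatter) and on the other core it gives a number 0.39 log units lower from compound 1 to compound 2 (beyond the scatter) even though the hydroxy enters at a different place on the ring. So the step carried over between these two cores, but two pairs set no rule for any further core or ring place. No measurement shown gives a reason for this match.

The compounds shown leave open whether another group put in the same place, such as an amine or a carboxylic acid, would shift the number by a similar amount. They also leave open what a second hydroxy would do on any third core.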